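A Smaller Branched Chain on the Carbamoyl Nitrogen

The source may report more compounds than this note shows. Statements on the series, on what has been measured and on what is new or still open speak of the compounds shown alone.

Compound 1, `CCCCCC(=O)OCC1CN(C(=O)c2cc(OC)c(OC)c(OC)c2)CCN1C(=O)c1cc(OC)c(OC)c(OC)c1`, gives 290 nM in a functional assay (Oryctolagus cuniculus) for inhibition of platelet-activating factor receptor (Cavia porcellus); a higher number here means a weaker inhibitor, a lower number a stronger inhibitor.
Compound 2, `CCCCCCCCCC(=O)OCC1CN(C(=O)c2cc(OC)c(OC)c(OC)c2)CCN1C(=O)c1cc(OC)c(OC)c(OC)c1`, gives 2820 nM in this assay.
Compound 3, `COc1cc(C(=O)N2CCN(C(=O)c3cc(OC)c(OC)c(OC)c3)C(COC(=O)NC(C)C(C)(C)C)C2)cc(OC)c1OC`, gives 170 nM in this assay.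

All three compounds share one core, and differ only in the group that hangs from the carbonyl carbon of the side chain. Compound 3 has the lowest number of the three; its gap to compound 1 is within the scatter, while compound 2 stands well apart from it. Compound 4, `CCC(C)CNC(=O)OCC1CN(C(=O)c2cc(OC)c(OC)c(OC)c2)CCN1C(=O)c1cc(OC)c(OC)c(OC)c1`, has not yet been measured. Relative to compound 3, the change is 2-methylbutyl in place of 1,2,2-trimethylpropyl on an amide-type nitrogen.

Two of the measured steps bear on this. The step of a 9.7-fold higher number from compound 1 to compound 2 (0.99 log units; beyond the scatter) shows that a much longer chain on the carbonyl carbon weakens inhibition. The step of a 1.7-fold lower number from compound 1 to compound 3 (0.23 log units; within the scatter) shows that swapping a plain chain for a branched amino group of similar size barely moves the number, and a 17-fold lower number from compound 2 to compound 3 (1.22 log units; beyond the scatter) mostly reflects the chain length again. The change from compound 3 to compound 4 keeps a branched chain of nearly the same size, so no step beyond the scatter is expected in this assay.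

For compound 4 the estimate is 200 nM, with a range from 80 nM to 500 nM, and the expected step is a 1.2-fold higher number from compound 3 to compound 4 (0.07 log units; within the scatter).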

Compound 4, half-maximal inhibitory concentration: 470 nM
For compound 4 the middle estimate is 2.4-fold (0.37 log units) below the measured one, and the stated range covers the measured number.
By their numbers in this assay, from the lowest: compounds 3, 1 and 4 (each within the scatter of the next, the first and the last beyond it); then compound 2.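

In this assay, the group on the amide-type nitrogen turns out to be sensitive to a small change: going from 1,2,2-trimethylpropyl, with 6 heavy atoms, to 2-methylbutyl, with 5, gives a 2.8-fold higher number from compound 3 to compound 4 (0.44 log units; beyond the scatter), whereas the earlier steps had shown a large change only for the much longer nonyl chain. The new group does not separate itself from the plain pentyl chain on the carbonyl carbon, with a 1.6-fold higher number from compound 1 to compound 4 (0.21 log units; within the scatter), so only (1,2,2-trimethylpropyl)amino, and not every branched amino group, gives a number clearly lower than compound 4's. Even so, (2-methylbutyl)amino keeps a clear advantage over nonyl on that carbonyl carbon, with a 6.0-fold lower number from compound 2 to compound 4 (0.78 log units; beyond the scatter), so the penalty attached to the nonyl chain is not restored by this swap.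

Nothing available here accounts for the gap between the two branched groups. Going by these compounds, this single pair changes the shape of the chain and its carbon count together, so it remains open whether an unbranched butyl or pentyl chain, or a cyclohexyl ring, on the same nitrogen would fall nearer compound 3 or compound 4.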